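A Larger Aromatic Cap on a Weak Caspase-8 Inhibitor

The source may hold more compounds than are shown below. What is called first, only, known or untested is meant among the compounds shown, and "the series" means these compounds.

Of the compounds shown here, three have been measured in an assay on isolated protein for inhibition of Caspase-8 (Homo sapiens); on this read-out lower numbers stand for stronger inhibition and higher numbers for weaker inhibition. Compound 1 `O=C1C[C@H](NC(=O)[C@@H]2CNC[C@@H]3CCCC[C@H](NC(=O)c4ccccc4)C(=O)N32)C(O)O1` gives 384 nM, compound 2 `O=C1C[C@H](NC(=O)[C@@H]2CN(C(=O)OCc3ccccc3)C[C@@H]3C/C=C\C[C@H](NC(=O)c4ccccc4)C(=O)N32)C(O)O1` gives 13 nM, and compound 3 `O=C1C[C@H](NC(=O)[C@@H]2COC[C@@H]3C/C=C\C[C@H](NC(=O)c4ccccc4)C(=O)N32)C(O)O1` gives 7900 nM, the highest number of the three, beyond the scatter from both compound 1 and compound 2. Compound 4 `O=C1C[C@H](NC(=O)[C@@H]2COC[C@@H]3C/C=C\C[C@H](NC(=O)c4ccc5ccccc5c4)C(=O)N32)C(O)O1` differs from compound 3 in one place: naphthalen-2-yl in place of phenyl on a carbonyl carbon. Within the data shown here, no measured pair shows this change on its own, so its size in this assay cannot be read from the data. A step of modest size is expected, with the direction uncertain, perhaps toward a lower number. The expected step from compound 3 to compound 4 is a 1.8-fold lower number from compound 3 to compound 4 (0.24 log units; within the scatter). Compound 4 is expected to give 4500 nM, within a range from 1000 nM to 20000 nM.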

Compound 4, half-maximal inhibitory concentration: 2590 nM
Estimate against measurement, compound 4: 1.7-fold (0.24 log units) above; low and high end bracket the measured number.
By their numbers in this assay, from the lowest: compound 2; then compound 1; then compound 4; then compound 3.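

In this assay, among these compounds, the change from benzoyl to (naphthalen-2-yl)carbonyl gives a 3.1-fold lower number from compound 3 to compound 4 (0.48 log units; beyond the scatter) and so provides the first direct reading at this position: the aromatic group on this carbonyl carbon affects the read-out, and the second aromatic ring goes with a modest step beyond the scatter. Nothing available accounts for this step. On these data alone, whether the same change gives a similar step on the core of compound 1 or compound 2 remains open. Also open, as far as these compounds go, is how a pyridin-3-yl or cyclohexyl group would read on this carbonyl carbon.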